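The source may hold more compounds than are shown below. What is called first, only, known or untested is meant among the compounds shown, and "the series" means these compounds.

In a functional assay on U-251 cells (Homo sapiens) for antiproliferative activity, read by MTT assay, with a stated time of 48 h (a lower number here means a stronger inhibitor, a higher number a weaker inhibitor), compound 1 `COc1cc(-c2cccc3nc(-c4cccc(Cl)c4)oc23)cc(OC)c1OC` gives 18500 nM. Compound 2 `COc1cc(-c2cccc3nc(-c4cccc(C)c4)oc23)cc(OC)c1OC` gives > 25000 nM, which is a limit of the assay and not a number. Compound 2 therefore has no exact position, only (the limit of > 25000 nM in this assay, at which 1 of the 2 values shown sits). Among the measured compounds shown here, the one measured step is an at least 1.3-fold higher number from compound 1 to compound 2 (0.13 log units; that floor lies within the scatter), with methyl in place of chloro on an aromatic carbon, and its floor stays within the usual scatter. Compound 3 `COc1cc(-c2cccc3nc(-c4ccco4)oc23)cc(OC)c1OC` keeps the shared core but carries furan-2-yl in place of 3-methylphenyl on an aromatic carbon. For the measured compounds named here, the measured step changed only one small group on the ring that now leaves, so it bears on this larger swap only indirectly, and no measured compound carries furan-2-yl. Going by the values given here, the expectation therefore leans on compound 1 at 18500 nM, the only exact number available, and no step beyond the scatter is expected in this assay, with no firm direction. The expected change is an at least 1.2-fold lower number from compound 2 to compound 3 (0.09 log units; that floor lies within the scatter). For compound 3, the estimated value is 20000 nM, with an expected range from 8000 nM to 45000 nM.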

Compound 3, half-maximal inhibitory concentration: 10600 nM
The estimate for compound 3 lay 1.9-fold (0.28 log units) above the measured number, within the range that was stated.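

Compared with the single small swap of methyl for chloro, this result shows that the whole ring at this place, on the aromatic carbon next to the ring nitrogen and next to the ring oxygen, can be exchanged in this assay without loss of activity. Among the compounds shown here, the step of an at least 2.3-fold lower number from compound 2 to compound 3 (0.37 log units; beyond the scatter) is the first one here that clears the scatter, yet the step of a 1.7-fold lower number from compound 1 to compound 3 (0.24 log units; within the scatter) does not, so furan-2-yl and 3-chlorophenyl cannot be told apart at this place. Compound 2 gives > 25000 nM, which is a limit of the assay and not a number, so the first of these steps has only a floor and its true size stays unknown: the limit of > 25000 nM in this assay, at which 1 of the 3 values shown sits.

Furan-2-yl differs from 3-methylphenyl in ring size, in its ring oxygen and in its hydrogen-bond acceptor, and these three compounds cannot separate those differences. As far as these compounds go, for compound 3, at 10600 nM, it also remains open whether a thiophene, a pyridine or a ring carrying an amine or a carboxylic acid at this place would give a clearly lower number.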